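This account rests on a few compounds, and the source may have more. Where it says the series, first, only, none or still open, it means among the compounds named here.

Measured so far in an assay on microsomes from intestine for inhibition of acyl-CoA:cholesterol acyltransferase (Oryctolagus cuniculus); a lower number here means a stronger inhibitor, a higher number a weaker inhibitor:
compound 1, `CCCCCCCC/C=C/CCCCCCCC(=O)Nc1ccccc1OC`, gives 8000 nM
compound 2, `CCCCCCCC/C=C/CCCCCCCC(=O)Nc1ccccc1CC`, gives 1200 nM
compound 3, `CCCCCCCC/C=C/CCCCCCCC(=O)Nc1ccccc1C(=O)c1ccccc1`, gives only a limit, > 10000 nM

Compound 2 holds the lowest of the two numbers in this assay; the step from compound 1 is a 6.7-fold lower number from compound 1 to compound 2 (0.82 log units; beyond the scatter), which is beyond the scatter. Compound 3 reports no number, only (the limit of > 10000 nM in this assay, at which 1 of the 3 values shown sits). Against compound 2 that limit means an at least 8.3-fold higher number from compound 2 to compound 3 (0.92 log units; beyond the scatter); against compound 1 it means an at least 1.2-fold higher number from compound 1 to compound 3 (0.09 log units; that floor lies within the scatter), a floor that lies within the scatter.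

Compound 4, `CCCCCCCC/C=C/CCCCCCCC(=O)Nc1ccc(OC)cc1OC`, is not yet measured. Relative to compound 2 the change is 2,4-dimethoxyphenyl in place of 2-ethylphenyl on an amide-type nitrogen. Going by the values given here, the one measured step that bears on it is the swap of ethyl for methoxy on an aromatic carbon, which gave a 6.7-fold lower number from compound 1 to compound 2 (0.82 log units; beyond the scatter). Compound 4 reverses that swap, putting a methoxy back on the ring, and adds a second methoxy for which no measured step exists among these compounds. The reversal alone points to a step back up toward the number of compound 1; the second methoxy is an open question. Compound 4 is therefore expected to land near compound 1, the step being a 6.7-fold higher number from compound 2 to compound 4 (0.82 log units; beyond the scatter), and its estimated value in this assay is 8000 nM, within 3000 nM to 20000 nM.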

Compound 4, half-maximal inhibitory concentration: 3000 nM
For compound 4 the middle estimate is 2.7-fold (0.43 log units) above the measured one; the measured number falls inside the stated range.
By their numbers in this assay, from the lowest: compound 2; then compound 4; then compound 1. At a limit, above all of these: compound 3.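

In this assay, methoxy in place of hydrogen on an aromatic carbon makes a difference of its own: a 2.7-fold lower number from compound 1 to compound 4 (0.43 log units; beyond the scatter), which gives the series its first measured step for a second methoxy on this ring. The 2,4-dimethoxyphenyl group thus recovers part of the ground lost with a single methoxy, but it does not match the 2-ethylphenyl group on the amide-type nitrogen: a 2.5-fold higher number from compound 2 to compound 4 (0.40 log units; beyond the scatter). A methoxy on the ring therefore does not fix the number near that of compound 1, although the data on hand give no cause for either step.

From the compounds shown here alone, it remains open whether the added methoxy would bring a similar gain on the ring of compound 2, as in a 2-ethyl-4-methoxyphenyl group, or whether the effect depends on the methoxy already present in compound 1. Also open, going by these compounds, is how this assay would read with an amine or a carboxylic acid on the ring, or with a longer chain on the carbonyl carbon.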